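The source may report more compounds than this note shows. Statements on the series, on what has been measured and on what is new or still open speak of the compounds shown alone.

Compound 1 `O=C1NC(=O)c2c1c1c(O)cccc1c1[nH]c3ccccc3c21`, compound 2 `O=c1ccc(=O)c2c1c1[nH]c3ccccc3c1c1c(=O)[nH]c(=O)c21` and compound 3 `O=c1ccc(=O)c2c1c1[nH]c3ccc(O)cc3c1c1c(=O)[nH]c(=O)c21` were tested in a functional assay on HCT-116 cells (Homo sapiens) for antiproliferative activity, with a stated time of 4 h; on this read-out lower numbers stand for stronger inhibition and higher numbers for weaker inhibition. Compound 1 gives 17500 nM, compound 2 gives 5300 nM, and compound 3 gives 15400 nM. The difference between the core of compound 1 and the core of compound 2 is not broken down here. Compound 3 comes from compound 2 by hydroxy in place of hydrogen on an aromatic carbon, and that step reads a 2.9-fold higher number from compound 2 to compound 3 (0.46 log units; beyond the scatter). Compound 4 `O=C1NC(=O)c2c1c1c(O)ccc(O)c1c1[nH]c3ccccc3c21`, not yet measured, comes from compound 1 by hydroxy in place of hydrogen on an aromatic carbon, the same kind of change, though here the place is ortho to a fused ring and para to a hydroxy group rather than para to a fused ring. Resting on compound 1 at 17500 nM and on the step of a 2.9-fold higher number from compound 2 to compound 3 (0.46 log units; beyond the scatter), the step from compound 1 to compound 4 is expected to be a 2.3-fold higher number from compound 1 to compound 4 (0.36 log units; beyond the scatter). Compound 4 is therefore estimated at 40000 nM in this assay, with a likely range from 15000 nM to 120000 nM.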

Compound 4, half-maximal inhibitory concentration: 3100 nM
Estimate against measurement, compound 4: 13-fold (1.11 log units) above, outside the stated range (below it).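

In this assay, hydroxy in place of hydrogen on an aromatic carbon gives a 5.6-fold lower number from compound 1 to compound 4 (0.75 log units; beyond the scatter), the opposite direction to the earlier step, so the effect of this change does not carry from one core to the other: the same change on two cores in this assay, a 2.9-fold higher number (0.46 log units; beyond the scatter) from compound 2 to compound 3 and a 5.6-fold lower number (0.75 log units; beyond the scatter) from compound 1 to compound 4, 16-fold (1.21 log units) apart, beyond the scatter of two such steps. The two steps also differ in where the hydroxy sits on the ring, so they do not separate the part played by the core from that played by the place. Each step has been seen only once, which shows no rule for other cores.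

The compounds shown leave open how hydroxy behaves at one matching place on both cores. They also leave open whether a methoxy group or an amine, para to a hydroxy group, would follow compound 4.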